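This account rests on a few compounds, and the source may have more. Where it says the series, first, only, none or still open, it means among the compounds named here.

Compound 2 `COc1ccc(S(=O)(=O)N(Cc2cccc(I)c2)[C@H](C)C(=O)O)cc1` gives 280 nM in an assay on isolated protein for inhibition of bone morphogenetic protein 1 (Homo sapiens) (on this read-out lower numbers stand for stronger inhibition and higher numbers for weaker inhibition), and compound 1 `COc1ccc(S(=O)(=O)N(Cc2ccc(Br)cc2F)[C@H](C)C(=O)O)cc1` gives 490 nM in this assay; the two numbers sit within the scatter of each other, as the step of a 1.8-fold lower number from compound 1 to compound 2 (0.24 log units; within the scatter) shows. Compound 3 `COc1ccc(S(=O)(=O)N(Cc2ccc(C(C)C)cc2)[C@H](C)C(=O)O)cc1` differs from compound 2 by 4-isopropylphenyl in place of 3-iodophenyl on a saturated chain carbon bound to a sulfonamide nitrogen. Going by the values given here, the only measured step, a 1.8-fold lower number from compound 1 to compound 2 (0.24 log units; within the scatter), concerns a different change and itself lies within the scatter, so no step beyond the scatter is expected in a 1.3-fold higher number from compound 2 to compound 3 (0.10 log units; within the scatter). Compound 3 is therefore estimated at 350 nM in this assay, with a range from 120 nM to 1000 nM.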

Compound 3, half-maximal inhibitory concentration: 350 nM
Beside the measured number, compound 3's estimate shows no gap at the digits printed, within the range that was stated.
By their numbers in this assay, from the lowest: compounds 2, 3 and 1 (each within the scatter of the next).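

With a 1.3-fold higher number from compound 2 to compound 3 (0.10 log units; within the scatter) and a 1.4-fold lower number from compound 1 to compound 3 (0.15 log units; within the scatter) in this assay, neither step leaves the scatter. Going by these compounds alone, on a saturated chain carbon bound to a sulfonamide nitrogen, 4-isopropylphenyl, which is built of carbon only, therefore reads alike with the iodine-bearing 3-iodophenyl and the 4-bromo-2-fluorophenyl of the earlier compounds. No independent measurement offers a reason for this. Still open, on these data alone, is whether a ring bearing an amine or a carboxylic acid at this place would move the number beyond the scatter.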